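The source may hold more compounds than are shown below. What is called first, only, known or untested is meant among the compounds shown, and "the series" means these compounds.

Compound 1 `CC[C@@H]1NC(=O)[C@H](CCCNC(=N)N)NC(=O)[C@](C)(NC(=O)C(C)C)CCCCN(C)C(=O)[C@@H](c2ccc(Cl)cc2)NC1=O` and compound 3 `CC[C@@H]1NC(=O)[C@H](CCCNC(=N)NC)NC(=O)[C@](C)(NC(=O)C(C)C)CCNC(=O)[C@@H](c2ccccc2)NC1=O` are peptide-like macrocycles, whereas compound 2 `CCC(CC)(NC(=O)C(C)C)C(=O)N[C@@H](CCCNC(=N)N)C(=O)NC1(C(=O)NC(c2ccccc2)c2ccccc2)CCCC1` is open-chain. In an ADME assay on microsomes (Rattus norvegicus) for metabolic stability (a lower number here means that the compound disappears faster, a higher number that the compound lasts longer), compound 2 gives 0.567 h. Compound 1 reaches only the limit of this assay, > 1 h, which is a limit and not a number. Compound 3 likewise reaches the limit, > 1 h, again a limit rather than a number, so it stands at the limit of > 1 h in this assay, at which 2 of the 3 values shown sit. Compound 4 `CC[C@@H]1NC(=O)[C@H](CCCNC(=N)N)NC(=O)[C@](C)(NC(=O)C(C)C)CCNC(=O)[C@@H](c2ccccc2)NC1=O` has not yet been measured in this assay. Compound 4 differs from compound 3 by hydrogen in place of methyl on an amine nitrogen. Compound 4 is expected to move by a step that the limit leaves unreadable from compound 3 to compound 4, nothing beyond the scatter, because compound 1 with amino in place of methylamino also sits at the limit of > 1 h in this assay, at which 2 of the 3 values shown sit. Compound 4 is therefore estimated to give 1.5 h in this assay, within a range from 0.7 h to 4 h.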

Compound 4, half-life: > 1 h
Compound 4 gave a limit, no number (the forecaster's own chance of this, stated with the estimate: 70%); the middle value is on the limit's open side.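

In this assay, among these compounds, compound 3 and compound 4 both give a limit, not a number, so no step between them can be read. The compounds shown leave open how long either compound actually lasts.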